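Methyl to ethyl on the anilide series

A few compounds are considered here, and "the series" means these few. Any claim that something is new, unique, unknown or untested is made for them only; others in the source may bear on it.

Values in a functional assay on MGC-803 cells (Homo sapiens) for inhibition, read by MTT assay, with a stated time of 72 h; on this read-out lower numbers stand for stronger inhibition and higher numbers for weaker inhibition
Compound 1 `O=C(Nc1ccccc1)C1CCN(C/C=C/c2ccccc2)CC1` gives 57900 nM
Compound 2 `Cc1ccc(NC(=O)C2CCN(C/C=C/c3ccccc3)CC2)cc1` gives 24100 nM
Compound 3 `CCc1ccc(NC(=O)C2CCN(C/C=C/c3ccccc3)CC2)cc1` has no value yet

Compound 2 holds the lower of the two numbers in this assay and compound 1 lies above it. Going to compound 3 puts methyl in place of hydrogen on a saturated chain carbon bound to an aromatic carbon and so turns 4-methylphenyl into 4-ethylphenyl. Among the compounds with values here, the only measured step that bears on this is a 2.4-fold lower number from compound 1 to compound 2 (0.38 log units; beyond the scatter) and it is modest, though beyond the scatter. That step placed methyl on an aromatic carbon, a different place from the one here. Within the data shown here, a further small fall in the number is expected, probably no larger than that step and possibly within the scatter. The expected change is a 1.5-fold lower number from compound 2 to compound 3 (0.18 log units; within the scatter) in this assay on this single precedent. Compound 3 is estimated at 16000 nM with an expected range from 6500 nM to 40000 nM in this series.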

Compound 3, half-maximal inhibitory concentration: 11600 nM
The estimate for compound 3 lay 1.4-fold (0.14 log units) above the measured number; the measured number falls inside the stated range.
By their numbers in this assay, from the lowest: compound 3; then compound 2; then compound 1.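

In this assay the change from 4-methylphenyl to 4-ethylphenyl gives a 2.1-fold lower number from compound 2 to compound 3 (0.32 log units; beyond the scatter) and so shows that the number can still fall when the added methyl sits on a saturated chain carbon bound to an aromatic carbon, whereas the earlier step placed methyl on an aromatic carbon only. Taking the two ends of the series together gives a 5.0-fold lower number from compound 1 to compound 3 (0.70 log units; beyond the scatter) and is the widest span in the three compounds, though still modest. Nothing measured here accounts for the fall in either step.

On these data alone, whether a longer chain such as propyl, or a branched one such as isopropyl, would lower the number further remains open. So does whether the trend holds for a group other than a plain alkyl chain, such as methoxy or an amine.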